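This account rests on a few compounds, and the source may have more. Where it says the series, first, only, none or still open, it means among the compounds named here.

compound 1 `CC(C)=CCC/C(C)=C/CC/C(C)=C/CC[C@@H]1[C@@]2(C)C/C(=C\c3ccc(OCc4cn(-c5ccccc5)nn4)cc3)C(=O)C(C)(C)[C@@H]2CC[C@@]1(C)O`: 36300 nM
compound 2 `CC(C)=CCC/C(C)=C/CC/C(C)=C/CC[C@@H]1[C@@]2(C)C/C(=C\c3ccc(OCc4cn(-c5ccccc5C#N)nn4)cc3)C(=O)C(C)(C)[C@@H]2CC[C@@]1(C)O`: 100000 nM
compound 3 `CC(C)=CCC/C(C)=C/CC/C(C)=C/CC[C@@H]1[C@@]2(C)C/C(=C\c3ccc(OCc4cn(-c5cccc([N+](=O)[O-])c5)nn4)cc3)C(=O)C(C)(C)[C@@H]2CC[C@@]1(C)O`: 32900 nM

In a functional assay on HeLa cells (Homo sapiens) for cytotoxicity, read by MTT assay, with a stated time of 48 h (a higher number here means a weaker inhibitor, a lower number a stronger inhibitor), compound 3 gives 32900 nM. That places it level with compound 1, the measured step being a 1.1-fold lower number from compound 1 to compound 3 (0.04 log units; within the scatter), and clear of the remaining member of the set, with a 3.0-fold lower number from compound 2 to compound 3 (0.48 log units; beyond the scatter).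

Compound 4 `CC(C)=CCC/C(C)=C/CC/C(C)=C/CC[C@@H]1[C@@]2(C)C/C(=C\c3ccc(OCc4cn(-c5ccc(F)c(Cl)c5)nn4)cc3)C(=O)C(C)(C)[C@@H]2CC[C@@]1(C)O` carries 3-chloro-4-fluorophenyl in place of 3-nitrophenyl on an aromatic nitrogen. Among the compounds with values here, no measured compound carries chlorine or fluorine, so the evidence is indirect. Two changes on this same phenyl ring bear on it. Adding the nitro group gave only a 1.1-fold lower number from compound 1 to compound 3 (0.04 log units; within the scatter), whereas adding the cyano group gave a modest 2.8-fold higher number from compound 1 to compound 2 (0.44 log units; beyond the scatter). Three compounds show that this ring can tolerate a substituent without a shift, but also that a shift can occur, and the one upward move argues for a wide range.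

In this assay, within the data shown here, the expected change is small, a 1.1-fold lower number from compound 3 to compound 4 (0.04 log units; within the scatter), with no step expected beyond the scatter. For compound 4 the estimated value is 30000 nM, with an expected range of 14000 nM to 70000 nM.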

Compound 4, half-maximal inhibitory concentration: 43000 nM
Estimate against measurement, compound 4: 1.4-fold (0.16 log units) below; the range from low to high includes it.
By their numbers in this assay, from the lowest: compounds 3, 1 and 4 (each within the scatter of the next); then compound 2.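

In this assay, 3-chloro-4-fluorophenyl on the aromatic nitrogen stands level with 3-nitrophenyl, a 1.3-fold higher number from compound 3 to compound 4 (0.12 log units; within the scatter), and with unsubstituted phenyl, a 1.2-fold higher number from compound 1 to compound 4 (0.07 log units; within the scatter). This adds a ring with two substituents, both halogens and neither a hydrogen-bond acceptor, to those that cause no shift at this position. Only 2-cyanophenyl stays apart, with a 2.3-fold lower number from compound 2 to compound 4 (0.37 log units; beyond the scatter), which makes it the one exception among the four compounds, and nothing measured here explains either the lack of shift or that exception.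

The compounds shown do not separate the effect of the nitrile group from that of its place on the ring. They also leave open whether an amine, a carboxylic acid or a hydroxyl on this phenyl ring would stay level with compounds 1, 3 and 4.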